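The compounds below may be only part of what the source reports. "The series", "measured", "known", "first", "only" and "open" are said of these compounds alone.

Values in an ADME assay on MT4 cells (Homo sapiens) for cytotoxicity, read by MTT assay; on this read-out lower numbers stand for higher toxicity in this test and higher numbers for lower toxicity in this test:
- compound 1 `O=C(CSc1nncnc1-c1ccccc1Cl)c1ccc(Cl)c(Cl)c1`: 33000 nM
- compound 2 `O=C(CSc1nncnc1-c1ccccc1Cl)Nc1ccccc1Br`: 73000 nM
- compound 3 `Cc1ccc(NC(=O)CSc2nncnc2-c2ccccc2Cl)c(Br)c1`: 45000 nM

Compound 3, at 45000 nM, lies within the usual scatter of both compound 1 and compound 2, so it holds no distinct rank among the three. Only the other pair is separated beyond the scatter, with a 2.2-fold higher number from compound 1 to compound 2 (0.34 log units; beyond the scatter).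

The next change leads to compound 4 `O=C(CSc1nncnc1-c1ccccc1Cl)Nc1cccnc1Cl`, with 2-chloropyridin-3-yl in place of 2-bromo-4-methylphenyl on an amide-type nitrogen.

Within the data shown here, two measured steps bear on this change, and neither matches it. The closer one, a 1.6-fold lower number from compound 2 to compound 3 (0.21 log units; within the scatter), stays within the scatter and alters the same aryl group only by methyl in place of hydrogen on an aromatic carbon. The other, a 2.2-fold higher number from compound 1 to compound 2 (0.34 log units; beyond the scatter), is modest and also changes what is attached to the carbonyl carbon. Among the measured compounds shown here, no measured compound carries a ring with a hetero atom at this place, so the direction is poorly defined and the range must stay wide.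

The estimated change is a 1.2-fold higher number from compound 3 to compound 4 (0.09 log units; within the scatter), and no shift beyond the scatter is expected. Compound 4 is expected at 55000 nM, within an estimated range of 25000 nM to 120000 nM.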

Compound 4, half-maximal cytotoxic concentration: 167000 nM
The estimate for compound 4 lay 3.0-fold (0.48 log units) below the measured number; the whole stated range lies below it.
By their numbers in this assay, from the lowest: compounds 1, 3 and 2 (each within the scatter of the next, the first and the last beyond it); then compound 4.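

In this assay, the 2-chloropyridin-3-yl group on an amide-type nitrogen gives the first clear shift among the amides of the series (a 3.7-fold higher number from compound 3 to compound 4 (0.57 log units; beyond the scatter)) and (a 2.3-fold higher number from compound 2 to compound 4 (0.36 log units; beyond the scatter)), whereas methyl in place of hydrogen on the aryl group had stayed within the scatter. Against the 3,4-dichlorophenyl group on a carbonyl carbon the step is the largest in the set (a 5.1-fold higher number from compound 1 to compound 4 (0.70 log units; beyond the scatter)), and compound 4 is the only compound here separated beyond the scatter from all the others, on the side of lower toxicity in this test. Even the closest comparison, with compound 2, exchanges a carbon-only ring for a ring with a hetero atom and bromine for chlorine together, and nothing available explains the size of the shift.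

Which of these two exchanges carries the step stays open, and a 2-chlorophenyl or a 2-bromopyridin-3-yl group on the same nitrogen would separate them. Also open, from the compounds shown here alone, is how far the trend extends to pyridine rings bearing an amine or a carboxylic acid in place of the chlorine.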